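A few compounds are considered here, and "the series" means these few. Any claim that something is new, unique, unknown or untested is made for them only; others in the source may bear on it.

The measured compounds, in a functional assay on MDA-MB-231 cells (Homo sapiens) for cytotoxicity, read by MTT assay, with a stated time of 72 h; on this read-out lower numbers stand for stronger inhibition and higher numbers for weaker inhibition:

Compound 1, `COc1cc2c(Oc3ccc(NC(=O)c4nn(-c5ccccc5)c(=O)c5ccccc45)cc3F)ccnc2cc1OCCCN1CCC(C)CC1`, gives 1480 nM.
Compound 2, `COc1cc2c(Oc3ccc(NC(=O)c4nn(-c5cccc(F)c5)c(=O)c5ccccc45)cc3F)ccnc2cc1OCCCN1CCC(C)CC1`, gives 860 nM.
Compound 3, `COc1cc2c(Oc3ccc(NC(=O)c4nn(-c5ccccc5F)c(=O)c5ccccc45)cc3F)ccnc2cc1OCCCN1CCC(C)CC1`, gives 670 nM.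

Compound 3 has the lowest of the three numbers in this assay. Its separation from compound 1 is real, a 2.2-fold lower number from compound 1 to compound 3 (0.34 log units; beyond the scatter), but against compound 2 the two values sit within the scatter of each other, a 1.3-fold lower number from compound 2 to compound 3 (0.11 log units; within the scatter), so compound 3 cannot be set apart from compound 2. The other measured step, a 1.7-fold lower number from compound 1 to compound 2 (0.24 log units; within the scatter), also stays within the scatter.

Compound 4, `COc1cc2c(Oc3ccc(NC(=O)c4nn(-c5ccccc5Br)c(=O)c5ccccc45)cc3F)ccnc2cc1OCCCN1CCC(C)CC1`, differs from compound 3 by bromo in place of fluoro on an aromatic carbon; cut one bond further out, the change reads 2-fluorophenyl to 2-bromophenyl, the exchange sitting ortho to a large group. Going by the values given here, none of the measured steps exchanges one halogen for another: a 2.2-fold lower number from compound 1 to compound 3 (0.34 log units; beyond the scatter) and a 1.7-fold lower number from compound 1 to compound 2 (0.24 log units; within the scatter) concern adding fluorine where hydrogen stood, and a 1.3-fold lower number from compound 2 to compound 3 (0.11 log units; within the scatter) concerns moving that fluorine from one position to another, and was within the scatter. The data therefore give no direct guide, and the expected step from compound 3 to compound 4 in this assay is none beyond the scatter, a 1.1-fold lower number from compound 3 to compound 4 (0.03 log units; within the scatter). Compound 4 is estimated at 620 nM, within a range from 250 nM to 1600 nM.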

Compound 4, half-maximal inhibitory concentration: 1240 nM
The estimate for compound 4 lay 2.0-fold (0.30 log units) below the measured number; measured number inside the range.
By their numbers in this assay, from the lowest: compounds 3, 2, 4 and 1 (each within the scatter of the next, the first and the last beyond it).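

In this assay, going by these compounds alone, this is the first exchange of one halogen for another on the ring, on the aromatic carbon ortho to a large group, and the step stays within the scatter (a 1.9-fold higher number from compound 3 to compound 4 (0.27 log units; within the scatter)), so the 2-fluorophenyl and 2-bromophenyl groups cannot be told apart here. Compound 4 also cannot be set apart from the other two compounds (a 1.4-fold higher number from compound 2 to compound 4 (0.16 log units; within the scatter); a 1.2-fold lower number from compound 1 to compound 4 (0.08 log units; within the scatter)), so bromo in place of hydrogen does not reproduce the separation beyond the scatter seen for fluoro in place of hydrogen (a 2.2-fold lower number from compound 1 to compound 3 (0.34 log units; beyond the scatter)). Nothing among the data shown accounts for these numbers.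

The compounds shown leave open how a chloro, methoxy, nitrile or amine group on this same aromatic carbon would read in this assay, and so whether any group here can move the number beyond the scatter from compound 3. They also leave open whether bromo on the aromatic carbon that carries fluoro in compound 2 would read as compound 2 does.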